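Replacing 4-fluorophenyl: from compound 3 to compound 4

This account rests on a few compounds, and the source may have more. Where it says the series, first, only, none or still open, it means among the compounds named here.

In a functional assay on HeLa cells (Homo sapiens) for antiproliferative activity, read by MTT assay, with a stated time of 72 h (a higher number here means a weaker inhibitor, a lower number a stronger inhibitor), compound 1 `Nc1nc(N)c2cc(CSC(=S)N3CCN(c4ccc(O)cc4)CC3)ccc2n1` gives 5180 nM, compound 2 `Nc1nc(N)c2cc(CSC(=S)N3CCN(c4ccc(Cl)cc4)CC3)ccc2n1` gives 6990 nM and compound 3 `Nc1nc(N)c2cc(CSC(=S)N3CCN(c4ccc(F)cc4)CC3)ccc2n1` gives 1840 nM, the lowest of the three numbers. The next structure, compound 4 `Nc1nc(N)c2cc(CSC(=S)N3CCN(c4ccccc4[N+](=O)[O-])CC3)ccc2n1`, has 2-nitrophenyl in place of 4-fluorophenyl on an amine nitrogen in a ring. The relevant measured steps are modest: a 2.8-fold lower number from compound 1 to compound 3 (0.45 log units; beyond the scatter) and a 3.8-fold lower number from compound 2 to compound 3 (0.58 log units; beyond the scatter). The remaining step, a 1.3-fold higher number from compound 1 to compound 2 (0.13 log units; within the scatter), shows no separation. For the measured compounds named here, no measured compound carries a nitro group, so this guide is indirect. The expected step is a 2.4-fold higher number from compound 3 to compound 4 (0.39 log units; beyond the scatter), a modest move to a higher number. The estimate for compound 4 is 4500 nM, with an expected range of 1500 nM to 12000 nM.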

Compound 4, half-maximal inhibitory concentration: 4880 nM
For compound 4 the middle estimate is 1.1-fold (0.04 log units) below the measured one; measured number inside the range.
By their numbers in this assay, from the lowest: compound 3; then compounds 4, 1 and 2 (each within the scatter of the next).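

Moving to 2-nitrophenyl on this ring nitrogen in this assay gives a 2.7-fold higher number from compound 3 to compound 4 (0.42 log units; beyond the scatter), so the larger group with hydrogen-bond acceptors does not match 4-fluorophenyl. It also fails to separate from the other two aryl groups, with a 1.4-fold lower number from compound 2 to compound 4 (0.16 log units; within the scatter) and a 1.1-fold lower number from compound 1 to compound 4 (0.03 log units; within the scatter), which leaves compound 3 as the only one of the four standing apart, the strongest here. No available evidence explains this difference. Still open, on these data alone, is whether 4-nitrophenyl or unsubstituted phenyl at this place would fall with compound 3 or with compounds 1, 2 and 4, which would help separate the nitro group itself from where it sits on the ring.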